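Amide substituent change on the highest-solubility compound

A few compounds are considered here, and "the series" means these few. Any claim that something is new, unique, unknown or untested is made for them only; others in the source may bear on it.

Compound 3 `CN(C)C(=O)c1ccncc1Nc1cc(-c2ccc3ccn(C)c3c2)c2nccnc2c1` gives the highest number of the three compounds in a physicochemical assay for solubility, read by spectrophotometry, measured as kinetic solubility, at pH 8, tested at 500 uM (on this read-out higher numbers stand for higher solubility and lower numbers for lower solubility), at 175 ug/mL. Compound 2 `CN1CCC(NS(=O)(=O)c2ccccc2Nc2cc(-c3ccc4ccn(C)c4c3)c3nccnc3c2)C1` gives 26 ug/mL in this assay, and compound 1 `CN(C)S(=O)(=O)c1ccccc1Nc1cc(-c2ccc3ccn(C)c3c2)c2nccnc2c1` gives 2 ug/mL, so compound 3 stands well above both. Compound 4 `CC(=O)N1CCOC(CNC(=O)c2ccncc2Nc2cc(-c3ccc4ccn(C)c4c3)c3nccnc3c2)C1` differs from compound 3 in one place: ((4-acetylmorpholin-2-yl)methyl)amino in place of dimethylamino on a carbonyl carbon. Among the measured compounds shown here, the only measured step of the same kind is a 13-fold higher number from compound 1 to compound 2 (1.11 log units; beyond the scatter), in which the dimethylamino was replaced by a larger amine carrying a hydrogen-bond donor, though on a sulfonyl sulfur rather than on a carbonyl carbon. For the measured compounds named here, that step is the sole guide here, and it points upward, yet compound 3 already starts from the highest number seen. Compound 4 is therefore expected to show a step of a 1.1-fold higher number from compound 3 to compound 4 (0.06 log units; within the scatter), a modest rise rather than a repeat of the larger change. The estimate for compound 4 in this assay is 200 ug/mL, with a range from 90 ug/mL to 270 ug/mL.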

Compound 4, solubility: 268 ug/mL
Beside the measured number, compound 4's estimate is 1.3-fold (0.13 log units) below it; low and high end bracket the measured number.
By their numbers in this assay, from the lowest: compound 1; then compound 2; then compounds 3 and 4 (each within the scatter of the next).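

In this assay, ((4-acetylmorpholin-2-yl)methyl)amino in place of dimethylamino on a carbonyl carbon gives a 1.5-fold higher number from compound 3 to compound 4 (0.19 log units; within the scatter), so this position accepts a much larger group carrying a six-membered ring without a step beyond the scatter. Among the compounds shown here, the only earlier step of this kind, on a sulfonyl sulfur and with a different amine entering, was a 13-fold higher number from compound 1 to compound 2 (1.11 log units; beyond the scatter), and that large step has no counterpart in this single pair at the carbonyl carbon. Nothing measured here accounts for the result.

The compounds shown leave open whether (1-methylpyrrolidin-3-yl)amino would give a larger step on this carbonyl carbon than the acetylated morpholine group does. They also leave open how the number would move with a piperazine or a chain ending in a carboxylic acid at this place.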